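Shortening the amide side chain in a hydrolase inhibitor series

A few compounds are considered here, and "the series" means these few. Any claim that something is new, unique, unknown or untested is made for them only; others in the source may bear on it.

Of the compounds shown here, two of a shared core have been measured in an assay on isolated protein for inhibition of ubiquitin carboxyl-terminal hydrolase 7 (Homo sapiens), with stated times of 30 min and 2 h; a lower number here means a stronger inhibitor, a higher number a weaker inhibitor. Compound 1 `Cn1nc2c(=O)n(CC3(O)CCN(Cc4ccc(-c5n[nH]c(=O)o5)cc4Cl)CC3)cnc2c1-c1ccc(CN)cc1` gives 171 nM. Going by the values given here, compound 2 `Cn1nc2c(=O)n(CC3(O)CCN(Cc4ccc(-c5ccco5)cc4Cl)CC3)cnc2c1-c1ccc(CNC=O)cc1` gives 20.9 nM, the lowest of the two numbers; the gap between compound 1 and compound 2 lies beyond the usual scatter, and since the two differ in more than one place, the pair shows only its two values and no single step.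

Compound 3 `Cn1nc2c(=O)n(CC3(O)CCN(Cc4ccc(-c5ccco5)cc4Cl)CC3)cnc2c1-c1ccc(C(N)=O)cc1` has not yet been measured. It differs from compound 2 in one place: carbamoyl in place of (formylamino)methyl on an aromatic carbon. The group that leaves and the group that enters each carry one hydrogen-bond donor and one hydrogen-bond acceptor, so the change mainly shortens the side chain by one atom.

Among the compounds with values here, no measured pair shows the effect of such a change here, so the expectation rests on compound 2 alone. Compound 3 is expected to stay close to compound 2, with a step of a 1.7-fold higher number from compound 2 to compound 3 (0.22 log units; within the scatter) that may not exceed the scatter. The estimate for compound 3 in this assay is 35 nM, within a range from 10 nM to 120 nM.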

Compound 3, half-maximal inhibitory concentration: 80.8 nM
Compound 3: middle estimate off by 2.3-fold (0.36 log units), on the low side, within the range that was stated.
By their numbers in this assay, from the lowest: compound 2; then compound 3; then compound 1.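

In this assay, putting carbamoyl in place of (formylamino)methyl gives a 3.9-fold higher number from compound 2 to compound 3 (0.59 log units; beyond the scatter), so this spot on the six-membered aromatic ring of carbon only, para to a large group, responds to a change of just this size. The two groups have the same hydrogen-bond donor and acceptor counts and differ in heavy atoms, 4 for the group that leaves and 3 for the one that enters, so matching those counts did not keep the number in place here. Nothing measured here tells which difference between the two groups accounts for the step.

The compounds shown leave open how a longer chain, such as (acetylamino)ethyl, or a carboxylic acid would fare at this position, so one step cannot yet show a trend with chain length. As far as these compounds go, compound 1 carries aminomethyl at this position but also differs from compound 2 and compound 3 elsewhere, so the effect of that amine on its own remains unknown.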